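Swapping chloro for methyl on a pyrazoline inhibitor

A few compounds are considered here, and "the series" means these few. Any claim that something is new, unique, unknown or untested is made for them only; others in the source may bear on it.

Two compounds have numbers in an assay for inhibition of cathepsin H (Capra hircus), using Lineweaver-Burk analysis; on this read-out lower numbers stand for stronger inhibition and higher numbers for weaker inhibition. Compound 1 `Cc1ccc(C2CC(c3ccccc3)=NN2c2ccccc2)cc1` carries a methyl group on one aromatic ring and a second phenyl ring on a nitrogen of the shared core; in this assay compound 1 gives 4180 nM. Compound 2 `Clc1ccc(C2CC(c3ccccc3)=NN2)cc1` carries a chloro group instead and no phenyl on that nitrogen; in this assay compound 2 gives 1560 nM. Compound 2 therefore stands at the lowest of the two numbers, and the gap to compound 1 lies beyond the usual scatter. Since compound 1 and compound 2 differ in two places at once, no single change can be read from them.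

Compound 3 `Cc1ccc(C2CC(c3ccccc3)=NN2)cc1` keeps the unsubstituted nitrogen of compound 2 and changes only the aromatic substituent: methyl in place of chloro on an aromatic carbon. Among the compounds with values here, no measured pair isolates this exchange, so the expectation rests on the two numbers alone. The expected step is a 1.4-fold higher number from compound 2 to compound 3 (0.15 log units; within the scatter), toward a slightly higher number and probably not beyond the scatter. For compound 3 the estimated inhibition constant is 2200 nM, with a range from 900 nM to 5500 nM.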

Compound 3, inhibition constant: 8200 nM
Beside the measured number, compound 3's estimate is 3.7-fold (0.57 log units) below it; measured number above the stated range.
By their numbers in this assay, from the lowest: compound 2; then compounds 1 and 3 (each within the scatter of the next).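

In this assay, the exchange of chloro for methyl on an aromatic carbon, para to a large group, can now be read on its own, and it gives a 5.3-fold higher number from compound 2 to compound 3 (0.72 log units; beyond the scatter) with nothing else in the molecule altered. This shows that the position is sensitive even to a swap between two small groups, each counted as a single heavy atom and neither bringing a ring, a hydrogen-bond donor or acceptor, or a charge. The other single change, hydrogen in place of phenyl on an amine nitrogen in a ring, gives a 2.0-fold higher number from compound 1 to compound 3 (0.29 log units; within the scatter) with methyl on the aromatic ring, so this read-out cannot separate compound 1 from compound 3, and nothing measured here explains either result.

Still open, as far as these compounds go, is whether the phenyl on that nitrogen would count for as little with chloro on the aromatic carbon. Also open, from the compounds shown here alone, is how other groups on that carbon, such as fluoro, methoxy or an amine, would compare with chloro and methyl.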